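This account rests on a few compounds, and the source may have more. Where it says the series, first, only, none or still open, it means among the compounds named here.

Measured so far in an ADME assay on NIH3T3 cells (Mus musculus) for cytotoxicity, read by MTT assay; a lower number here means a stronger inhibitor, a higher number a weaker inhibitor:

- compound 1 `N#Cc1c(-c2ccccc2)c(C#N)c(=O)n(/N=C/c2cn(-c3ccccc3)nc2-c2ccccc2)c1N`: 180 ug/mL
- compound 2 `N#Cc1c(-c2ccccc2Cl)c(C#N)c(=O)n(/N=C/c2cn(-c3ccccc3)nc2-c2ccccc2)c1N`: 84 ug/mL
- compound 3 `N#Cc1c(-c2ccc(F)cc2)c(C#N)c(=O)n(/N=C/c2cn(-c3ccccc3)nc2-c2ccccc2)c1N`: a limit of the assay, > 200 ug/mL

Compound 2 has the lowest of the two numbers; its nearest neighbour is compound 1, the step being a 2.1-fold lower number from compound 1 to compound 2 (0.33 log units; beyond the scatter). Compound 3 sits at the limit of > 200 ug/mL in this assay, at which 1 of the 3 values shown sits, so the step of an at least 2.3-fold higher number from compound 2 to compound 3 (0.37 log units; beyond the scatter) is known only as a floor.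

Compound 4 `COc1cc(-c2c(C#N)c(N)n(/N=C/c3cn(-c4ccccc4)nc3-c3ccccc3)c(=O)c2C#N)cc(OC)c1OC` is not yet measured. It differs from compound 2 by 3,4,5-trimethoxyphenyl in place of 2-chlorophenyl on an aromatic carbon. Going by the values given here, two measured steps touch this change. Removing the chloro reverses a 2.1-fold lower number from compound 1 to compound 2 (0.33 log units; beyond the scatter), which would push the number up by a modest amount. Replacing the whole ring as in an at least 2.3-fold higher number from compound 2 to compound 3 (0.37 log units; beyond the scatter) also moved the number up, though only a floor is known. Nothing measured bears on the trimethoxy groups themselves.

On that basis a modest rise is expected, with the step from compound 2 to compound 4 estimated at a 1.8-fold higher number from compound 2 to compound 4 (0.25 log units; within the scatter). Compound 4 is therefore expected to give about 150 ug/mL in this assay, within a range from 70 ug/mL to 200 ug/mL.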

Compound 4, half-maximal inhibitory concentration: 64 ug/mL
Beside the measured number, compound 4's estimate is 2.3-fold (0.37 log units) above it; measured number below the stated range.
By their numbers in this assay, from the lowest: compounds 4 and 2 (each within the scatter of the next); then compound 1. At a limit, above all of these: compound 3.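

In this assay, at the position opposite the ring nitrogen, 3,4,5-trimethoxyphenyl and 2-chlorophenyl cannot be told apart, with a 1.3-fold lower number from compound 2 to compound 4 (0.12 log units; within the scatter), so chlorine is not required for a reading of this order. Compound 4 also separates from the unsubstituted phenyl, with a 2.8-fold lower number from compound 1 to compound 4 (0.45 log units; beyond the scatter), making it the second substituted ring to do so after compound 2. Compound 3 goes against any general rule for substituted rings, and its value is a limit of the assay, so an at least 3.1-fold lower number from compound 3 to compound 4 (0.49 log units; beyond the scatter) is only a floor: the limit of > 200 ug/mL in this assay, at which 1 of the 4 values shown sits.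

Open, as far as these compounds go, is whether a single methoxy at the 4-position of the phenyl, or a 3,5-dimethoxyphenyl, would read like the 3,4,5-trimethoxyphenyl. Also open, from the compounds shown here alone, is how a dimethylamino group or a carboxylic acid on this ring, or a pyridyl ring in place of the phenyl, would read in this assay.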